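Lengthening the acetyl group of compound 2

This account rests on a few compounds, and the source may have more. Where it says the series, first, only, none or still open, it means among the compounds named here.

- compound 1 `COc1ccc(NC(=O)CSC(=S)N[C@H]2CCOC2=O)cc1`: 62100 nM
- compound 2 `CC(=O)c1ccc(NC(=O)CSC(=S)N[C@H]2CCOC2=O)cc1`: 99400 nM

In a functional assay on MGC-803 cells (Homo sapiens) for cytotoxicity, read by MTT assay, with a stated time of 72 h (a higher number here means a weaker inhibitor, a lower number a stronger inhibitor), compound 2 gives 99400 nM, within the scatter of compound 1 at 62100 nM. Compound 3 `O=C(CSC(=S)N[C@H]1CCOC1=O)Nc1ccc(C(=O)/C=C/c2ccccc2Cl)cc1` differs from compound 2 at one place: 2-(2-chlorophenyl)ethenyl in place of methyl on a carbonyl carbon. Within the data shown here, the only measured step, a 1.6-fold higher number from compound 1 to compound 2 (0.20 log units; within the scatter), placed acetyl where methoxy stood and stayed within the scatter, so it offers little guidance on this larger change. Among the measured compounds shown here, no measured step adds such a group. A lower number beyond the scatter is nevertheless expected in this assay, with wide uncertainty. The estimated step is a 6.6-fold lower number from compound 2 to compound 3 (0.82 log units; beyond the scatter). Compound 3 is expected at 15000 nM, within an estimated range of 3000 nM to 70000 nM.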

Compound 3, half-maximal inhibitory concentration: 12400 nM
Estimate against measurement, compound 3: 1.2-fold (0.08 log units) above; the range from low to high includes it.
By their numbers in this assay, from the lowest: compound 3; then compounds 1 and 2 (each within the scatter of the next).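

In this assay, among these compounds, the change from methyl to 2-(2-chlorophenyl)ethenyl on the carbonyl carbon gives an 8.0-fold lower number from compound 2 to compound 3 (0.90 log units; beyond the scatter) and is the first step here beyond the scatter. This carbonyl carbon therefore tolerates a far larger group, with an added aromatic ring and a double bond, and the number falls rather than rises. Nothing measured here explains the drop.

Still open, on these data alone, is which part of the entering group matters: the chlorine, the double bond or the ring. A 2-phenylethenyl group without chlorine, or a saturated 2-phenylethyl chain, would help separate them.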